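This account rests on a few compounds, and the source may have more. Where it says the series, first, only, none or still open, it means among the compounds named here.

Three compounds built on one shared core were measured in a functional assay (Oryctolagus cuniculus) for antagonist activity at platelet-activating factor receptor (Cavia porcellus); on this read-out lower numbers stand for stronger inhibition and higher numbers for weaker inhibition. Compound 1 `CN(C)C(=O)n1cc(C(=O)c2ccn3c2CSC3c2cccnc2)c2ccc(Cl)cc21` carries a chloro group on the aromatic ring of its fused system, and in this assay compound 1 gives 89 nM. Compound 2 `CN(C)C(=O)n1cc(C(=O)c2ccn3c2CSC3c2cccnc2)c2ccc(Cc3ccccc3)cc21` carries a benzyl group on that carbon instead, and in this assay compound 2 gives 13 nM. Compound 3 `CN(C)C(=O)n1cc(C(=O)c2ccn3c2CSC3c2cccnc2)c2ccc(-c3ccccc3)cc21` carries a phenyl group there, and in this assay compound 3 gives 23 nM. Among the three numbers compound 3 stands second highest: the step of a 3.9-fold lower number from compound 1 to compound 3 (0.59 log units; beyond the scatter) lies beyond the scatter, while the step of a 1.8-fold higher number from compound 2 to compound 3 (0.25 log units; within the scatter) does not.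

Compound 4 `CN(C)C(=O)n1cc(C(=O)c2ccn3c2CSC3c2cccnc2)c2ccc(Oc3ccc(F)cc3)cc21` differs from compound 3 by 4-fluorophenoxy in place of phenyl on an aromatic carbon. For the measured compounds named here, two steps bear on this. The step of a 3.9-fold lower number from compound 1 to compound 3 (0.59 log units; beyond the scatter) shows that a ring-bearing group in place of chloro lowers the number, and the step of a 1.8-fold higher number from compound 2 to compound 3 (0.25 log units; within the scatter) shows that benzyl and phenyl give much the same result. Since 4-fluorophenoxy is again a ring-bearing group, the step expected in this assay is a 1.4-fold lower number from compound 3 to compound 4 (0.16 log units; within the scatter), nothing beyond the scatter. Compound 4 is therefore estimated to give about 16 nM in this assay, with a likely range from 6 nM to 45 nM.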

Compound 4, inhibition constant: 1.7 nM
Compound 4: middle estimate off by 9.4-fold (0.97 log units), on the high side, outside the stated range (below it).
By their numbers in this assay, from the lowest: compound 4; then compounds 2 and 3 (each within the scatter of the next); then compound 1.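

At this aromatic carbon, a ring-bearing group does not settle the outcome on its own, as the near match of benzyl and phenyl might have suggested. In this assay, 4-fluorophenoxy gives a 14-fold lower number from compound 3 to compound 4 (1.13 log units; beyond the scatter) and a 7.6-fold lower number from compound 2 to compound 4 (0.88 log units; beyond the scatter), so it stands apart from both of the other ring-bearing groups, with both steps beyond the scatter. Against the small chloro group, the change amounts to a 52-fold lower number from compound 1 to compound 4 (1.72 log units; beyond the scatter) and makes compound 4 the strongest inhibitor of the four, so this position can move the read-out much further than the earlier compounds showed.

No measurement shown here explains why this group behaves so differently. The compounds also leave open whether the oxygen or the fluorine accounts for the step, and how a plain phenoxy group or an amine at this carbon would compare.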